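Swapping the aryl group of compound 3 for an aminopyridine

This account rests on a few compounds, and the source may have more. Where it says the series, first, only, none or still open, it means among the compounds named here.

In an in vivo ADME assay on the whole organism for pharmacokinetics, with Rattus norvegicus as the target, at a dose of 10 mg/kg by the oral route (on this read-out lower numbers stand for lower exposure and higher numbers for higher exposure at the dose given), compound 3 `CC(C)c1cc(CS(=O)(=O)N2CCN(c3cnn(-c4cccc(Cl)c4)c(=O)c3OCC3(C)CC3)CC2)ccc1N` stands lowest of the three measured compounds, at 1190 nM. Compound 1 `COc1cc(CS(=O)(=O)N2CCN(c3cnn(-c4cccc(Cl)c4)c(=O)c3OCC3(C)CC3)CC2)ccc1N` gives 5750 nM and compound 2 `CCc1cc(CS(=O)(=O)N2CCN(c3cnn(-c4cccc(Cl)c4)c(=O)c3OCC3(C)CC3)CC2)ccc1N` gives 4020 nM, and the step between them, a 1.4-fold lower number from compound 1 to compound 2 (0.16 log units; within the scatter), stays within the scatter. Two modest steps lead down to the isopropyl compound: a 4.8-fold lower number from compound 1 to compound 3 (0.68 log units; beyond the scatter) and a 3.4-fold lower number from compound 2 to compound 3 (0.53 log units; beyond the scatter).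

Compound 4 `CC1(COc2c(N3CCN(S(=O)(=O)Cc4cccnc4N)CC3)cnn(-c3cccc(Cl)c3)c2=O)CC1` differs from it at a new place in the series: 2-aminopyridin-3-yl in place of 4-amino-3-isopropylphenyl on a saturated chain carbon bound to a sulfonyl sulfur. Among the compounds with values here, no measured compound carries this group, so the measured steps guide the expectation only loosely. The isopropyl group leaves in this change, and its arrival went with a 3.4-fold lower number from compound 2 to compound 3 (0.53 log units; beyond the scatter). A modest rise of similar size is therefore expected, a 2.5-fold higher number from compound 3 to compound 4 (0.40 log units; beyond the scatter). For compound 4 the estimated value is 3000 nM, with an expected range from 900 nM to 9000 nM.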

Compound 4, maximal plasma concentration: 3120 nM
The estimate for compound 4 lay 1.0-fold (0.02 log units) below the measured number; the measured number falls inside the stated range.
By their numbers in this assay, from the lowest: compound 3; then compounds 4, 2 and 1 (each within the scatter of the next).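

Until now only the substituent on the aniline ring had varied, and compound 4 shows that in this assay the whole aryl group on the saturated chain carbon bound to a sulfonyl sulfur can change, with a 2.6-fold higher number from compound 3 to compound 4 (0.42 log units; beyond the scatter). The other two steps, a 1.3-fold lower number from compound 2 to compound 4 (0.11 log units; within the scatter) and a 1.8-fold lower number from compound 1 to compound 4 (0.27 log units; within the scatter), stay within the scatter, so 2-aminopyridin-3-yl, with its smaller count of heavy atoms, leaves compound 3 as the only one of the four that stands apart. Nothing shown here explains the rise.

Going by these compounds, compound 4 loses the isopropyl group and gains a ring nitrogen in a single change, and the share of each in the step stays open. A 4-aminophenyl group without a substituent, or a 2-aminopyridin-3-yl group bearing an isopropyl group, would separate the two.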